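Propyl in Place of 4-Chlorophenyl on the Core

This account rests on a few compounds, and the source may have more. Where it says the series, first, only, none or still open, it means among the compounds named here.

Measured compounds:
compound 1, `CC1=C(C(=O)OCc2ccccn2)C(c2ccc(Cl)cc2)C2=C(CCCC2=O)N1`, 2.24
compound 2, `CC1=C(C(=O)OCc2cccnc2)C(c2cccc(O)c2)C2=C(CCCC2=O)N1`, 1.21

In a physicochemical assay for lipophilicity, measured as octanol-water partition (on this read-out higher numbers stand for higher lipophilicity and lower numbers for lower lipophilicity), compound 1 gives 2.24 and compound 2 gives 1.21. Of the two numbers compound 1 stands highest, its nearest neighbour being compound 2, a gap beyond the usual scatter. Compound 3, `CCCC1C(C(=O)OCc2ccccn2)=C(C)NC2=C1C(=O)CCC2`, has not yet been measured in this assay. It differs from compound 1 as follows: propyl in place of 4-chlorophenyl on a saturated ring carbon. Going by the values given here, no step between measured compounds shows what this change does, so the expectation rests on the change itself. Compound 3 is expected to sit below compound 1 by a step beyond the scatter, a number 0.94 log units lower from compound 1 to compound 3 (beyond the scatter). For compound 3 the estimate is 1.3, within a range from 0.7 to 1.9.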

Compound 3, partition coefficient: 2.6
Beside the measured number, compound 3's estimate is 1.30 log units below it; measured number outside the range, above it.
By their numbers in this assay, from the lowest: compound 2; then compound 1; then compound 3.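

In this assay, propyl in place of 4-chlorophenyl on a saturated ring carbon gives a number 0.36 log units higher from compound 1 to compound 3 (beyond the scatter). This position therefore does not need the aromatic ring to hold the number up, as a chain with no ring here reads higher, at least on the shared core of this pair. Nothing shown explains the direction of this step.

As far as these compounds go, whether the rise belongs to propyl itself or to the loss of 4-chlorophenyl remains open. So does what a plain phenyl, a longer chain such as hexyl, or an amine would do on this carbon.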